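Urea series: swapping the amide-nitrogen aryl of compound 1

A few compounds are considered here, and "the series" means these few. Any claim that something is new, unique, unknown or untested is made for them only; others in the source may bear on it.

Three ureas have numbers in an assay on isolated protein for inhibition of serine/threonine-protein kinase 10 (Homo sapiens), read by thermal shift assay, tested at 10 uM (on this read-out higher numbers stand for stronger stabilisation of the target against heat and lower numbers for weaker stabilisation of the target), so far. Compound 1 `Cc1ccccc1NC(=O)Nc1cc(C(C)(C)C)nn1-c1ccccc1` gives 8.6 degrees C and stands highest of the three. Compound 3 `Cn1nc(-c2ccccc2)cc1NC(=O)Nc1cc(C(F)(F)F)cc(C(F)(F)F)c1` gives 2.6 degrees C, the nearest to it, and compound 2 `Cn1nc(C(C)(C)C)cc1NC(=O)Nc1cc(C(F)(F)F)cc(C(F)(F)F)c1` gives 1.1 degrees C, the furthest. Going by the values given here, the one single-point step measured is a number 1.5 degrees C higher from compound 2 to compound 3 (beyond the scatter), a change on an aromatic carbon of the shared core, not at the amide-type nitrogen.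

Compound 4 `CC(C)(C)c1cc(NC(=O)Nc2cc(F)cc(F)c2)n(-c2ccccc2)n1` is still to be measured in this assay. It differs from compound 1 by 3,5-difluorophenyl in place of 2-methylphenyl on an amide-type nitrogen. Among the compounds with values here, no measured step touches this position: compounds 2 and 3 differ from compound 1 in more than one place, so their values do not isolate the effect of the group on the amide-type nitrogen. The only clue is that both compounds carrying a different aryl there sit well under compound 1, which gives no clean direction but leaves a drop as the more likely case.

For compound 4 a number lower than compound 1 is therefore expected, the estimated step being a number 3.1 degrees C lower from compound 1 to compound 4 (beyond the scatter). Compound 4 is estimated at 5.5 degrees C, within a wide range from 2 degrees C to 9 degrees C.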

Compound 4, shift of the target's melting temperature: 2.5 degrees C
Estimate against measurement, compound 4: 3.0 degrees C above; measured number inside the range.
By their numbers in this assay, from the lowest: compound 2; then compounds 4 and 3 (each within the scatter of the next); then compound 1.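

The group on the amide-type nitrogen now has its first clean reading: in this assay, 3,5-difluorophenyl in place of 2-methylphenyl gives a number 6.1 degrees C lower from compound 1 to compound 4 (beyond the scatter), a large step with the rest of the structure unchanged. Going by these compounds alone, the read-out therefore responds strongly to the aryl group at this position, which the only earlier step could not show, since the change from compound 2 to compound 3 lay on an aromatic carbon of the core. No data at hand bear on the origin of this step.

This single swap removes the methyl group and adds two fluorines at once, so it cannot say whether the drop follows the loss of the one or the entry of the other; plain unsubstituted phenyl on the same nitrogen would begin to separate the two. It also leaves open whether the position needs an aromatic carbon ring at all, a question that cyclohexyl or a pyridine ring in place of 2-methylphenyl would address.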